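A few compounds are considered here, and "the series" means these few. Any claim that something is new, unique, unknown or untested is made for them only; others in the source may bear on it.

In an ADME assay on microsomes from liver (Mus musculus) for metabolic stability, read by LC-MS, with a stated time of 30 min, tested at 1 uM (a higher number here means that more of the compound is left, a lower number that less of the compound is left), three related compounds have been measured: compound 1 (`O=C(NCc1ccc(S(=O)(=O)c2ccccc2)cc1)c1nc2ccncc2s1`) gives 26%, compound 2 (`O=C(NCc1ccc(S(=O)(=O)c2ccccc2)cc1)c1ccc2nccn2c1`) gives 18% and compound 3 (`O=C(NCc1ccc(S(=O)(=O)c2ccccc2)cc1)c1ccc2cnccc2c1`) gives 10%. Compound 2 therefore lies within the scatter of both compound 1 and compound 3. Compound 4 (`O=C(NCc1ccc(S(=O)(=O)c2ccccc2)cc1)c1ccc2nncn2c1`) has not yet been measured and differs from compound 2 by a group of 9 heavy atoms (6 carbon, 3 nitrogen; one five-membered aromatic ring with 3 hetero atoms, one six-membered aromatic ring with 1 hetero atom) in place of a group of 9 heavy atoms (7 carbon, 2 nitrogen; one five-membered aromatic ring with 2 hetero atoms, one six-membered aromatic ring with 1 hetero atom), on a carbonyl carbon. Within the data shown here, the only measured step of this kind is a number 8 percentage points lower from compound 1 to compound 2 (within the scatter), which also exchanges the group on the carbonyl carbon. No step beyond the scatter is therefore expected in this assay, and the estimated change is a number 4 percentage points higher from compound 2 to compound 4 (within the scatter). For compound 4 the expected value is 22%, with an estimated range from 9% to 40%.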

Compound 4, percent of the compound remaining: 47%
Compound 4: the middle estimate sits 25 percentage points below what was measured; measured number outside the range, above it.
By their numbers in this assay, from the lowest: compounds 3, 2 and 1 (each within the scatter of the next, the first and the last beyond it); then compound 4.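

In this assay, among these compounds, the group on the carbonyl carbon can shift the number beyond the scatter: a number 29 percentage points higher from compound 2 to compound 4 (beyond the scatter), and a number 21 percentage points higher from compound 1 to compound 4 (beyond the scatter), whereas the one earlier step at this place, a number 8 percentage points lower from compound 1 to compound 2 (within the scatter), did not show this. The change from 2 to 3 hetero atoms in the five-membered aromatic ring comes with the heavy-atom count unchanged at 9. Nothing at hand bears on why the step occurs.

The compounds shown leave open whether a methyl group or an amine on the group entering in compound 4 would keep this number. On these data alone, it also remains open whether the exchange gives a similar step when the rest of the shared core carries a fluorine.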